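The compounds below may be only part of what the source reports. "The series", "measured", "known", "first", "only" and "open" are said of these compounds alone.

Working notes on the series.

The series shares one core. Compound 1 is `COC(=O)c1c(Nc2ccc(C)cc2)sc(C(=O)c2ccc(OC)cc2)c1C` and compound 2 is `COC(=O)c1c(Nc2ccc(OC)cc2)sc(C(=O)c2ccc(OC)cc2)c1C`; the two differ only in the group on the aniline ring. In a functional assay, with a stated time of 150 min, tested at 20 ug/mL (on this read-out lower numbers stand for a weaker effect and higher numbers for a stronger effect at the one concentration tested), compound 1 gives "not active" (no number reported), an entry without a number. In this assay compound 2 gives 12%, the only number shown in the series so far, so compound 2 stands alone among the measured entries, and nothing can be said of its rank against compound 1 beyond this. For the measured compounds named here, no step between measured compounds is available, so the scatter of the read-out is the only yardstick.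

Compound 3 is `COc1ccc(Nc2sc(C(=O)c3ccc(OC)cc3)c(C)c2C(=O)O)cc1`, not yet measured in this assay. Its change from compound 2 is hydrogen in place of methyl on an oxygen next to a carbonyl group.

Going by the values given here, with no measured step to rest on, the expectation for compound 3 is that the change brings no movement beyond the scatter, with the estimated step from compound 2 to compound 3 being a number 2 percentage points lower from compound 2 to compound 3 (within the scatter). Compound 3 is therefore expected to give 10% in this assay, within a range from 0% to 25%, because compound 2 gives 12% and that weak read-out is the only anchor.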

Compound 3, a percentage reported as activity, at one concentration (the size of the read-out at that concentration, not a potency): 32.5%
Compound 3: the middle estimate sits 22.5 percentage points below what was measured; measured number outside the range, above it.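

For the compounds shown here, the change from methoxycarbonyl to carboxy, with hydrogen in place of methyl on an oxygen next to a carbonyl group, gives the first readable step: in this assay there is a number 20.5 percentage points higher from compound 2 to compound 3 (beyond the scatter). Going by these compounds alone, this position is therefore not silent, as the read-out responds to this single change, something the earlier compounds could not show, since the only pair among them has one entry without a number. The step describes the size of the effect at the one concentration tested, not a potency, and no measurement bearing on the reason for the step is available.

The compounds shown leave open whether the step belongs to the free carboxy group specifically, since an amide, a primary carboxamide, an ethyl ester or a longer chain ester at the same place would be needed to separate the hydrogen from the rest of the group. They also leave open whether the same change gives a comparable step with the methyl-bearing aniline ring of compound 1, or with other groups on that ring, such as an amine or a halogen like chlorine.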